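Replacing a hydroxy-thioether side chain with a chlorobenzyl group

This account rests on a few compounds, and the source may have more. Where it says the series, first, only, none or still open, it means among the compounds named here.

The measured compounds are:

Compound 1, `CCn1c(=O)n(C2OC(CO)[C@@H](O)[C@H]2O)c2nc(N)nc(O)c21`: 15 uM
Compound 2, `NCC(O)Cn1c(=O)n(C2OC(CO)[C@@H](O)[C@H]2O)c2nc(N)nc(O)c21`: 28 uM
Compound 3, `Nc1nc(O)c2c(n1)n(C1OC(CO)[C@@H](O)[C@H]1O)c(=O)n2CC(O)CSc1ccccc1`: 142 uM

All three share one core and differ only in the group on a saturated chain carbon bound to an aromatic nitrogen. In a functional assay (B cells) with Mus musculus as the target (a lower number here means that less compound is needed, a higher number that more compound is needed for the effect), compound 1 gives 15 uM. The change to compound 2 brought a 1.9-fold higher number from compound 1 to compound 2 (0.27 log units; within the scatter). Compound 3 stands highest of the three numbers in this assay; the nearest is compound 2, and the step was a 5.1-fold higher number from compound 2 to compound 3 (0.71 log units; beyond the scatter), while against compound 1 the step was a 9.5-fold higher number from compound 1 to compound 3 (0.98 log units; beyond the scatter).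

Compound 4, `Nc1nc(O)c2c(n1)n(C1OC(CO)[C@@H](O)[C@H]1O)c(=O)n2Cc1ccc(Cl)cc1`, has not been measured in this assay. It differs from compound 3 as follows: 4-chlorophenyl in place of 1-hydroxy-2-(phenylsulfanyl)ethyl on a saturated chain carbon bound to an aromatic nitrogen. For the measured compounds named here, the steps that bear on this change are those from compound 1 and compound 2 to compound 3, where the larger side chain carrying the phenylsulfanyl group went with a higher number. Compound 4 keeps an aromatic ring at that position but drops the hydroxyl and sulfur, so a number somewhat lower than that of compound 3 is expected, though likely not as low as compound 1. This corresponds to an expected 2.8-fold lower number from compound 3 to compound 4 (0.45 log units; beyond the scatter). Compound 4 is therefore estimated at 50 uM, with a range of 15 uM to 150 uM.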

Compound 4, concentration for half-maximal effect: 14 uM
Compound 4: the middle estimate sits 3.6-fold (0.55 log units) above what was measured; measured number below the stated range.
By their numbers in this assay, from the lowest: compounds 4, 1 and 2 (each within the scatter of the next); then compound 3.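

In this assay an aromatic ring at this place does not by itself go with a high number, since 4-chlorophenyl carries one just as 1-hydroxy-2-(phenylsulfanyl)ethyl does, and yet the exchange gave a 10-fold lower number from compound 3 to compound 4 (1.01 log units; beyond the scatter), a large step. Set against the other two groups, 4-chlorophenyl cannot be told apart, with a 2.0-fold lower number from compound 2 to compound 4 (0.30 log units; within the scatter) and a 1.1-fold lower number from compound 1 to compound 4 (0.03 log units; within the scatter), so methyl, 2-amino-1-hydroxyethyl and 4-chlorophenyl on a saturated chain carbon bound to an aromatic nitrogen all lie within the scatter of one another, and among the four compounds only compound 3 stands apart. Nothing measured here accounts for the large step away from compound 3.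

The exchange removes the hydroxyl and the sulfur and brings in the chlorine all at once, so the compounds shown do not tell which of these parts goes with the change in number. A plain phenyl without the chlorine, a 4-methoxyphenyl, or a phenylsulfanyl chain without its hydroxyl would each separate these parts, and the same holds for an amine or a carboxylic acid on the ring.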